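The compounds below may be only part of what the source reports. "The series", "measured", "known", "first", "only" and "open" are said of these compounds alone.

Compound 2 `CCn1c(=O)c2nc(-c3ccc(S(=O)(=O)N4CCOCC4)cc3)[nH]c2n(CC)c1=O` is the starting point of this step. In an assay for binding affinity to adenosine receptor A1 (Bos taurus) (on this read-out lower numbers stand for stronger inhibition and higher numbers for weaker inhibition), compound 2 gives 13 nM. Among the three compounds measured so far it holds the second highest number: compound 1 `CCn1c(=O)c2nc(-c3ccc(S(=O)(=O)O)cc3)[nH]c2n(CC)c1=O` gives 755 nM, while compound 3 `CCc1ccc(-c2nc3c(=O)n(C)c(=O)n(C)c3[nH]2)cc1` gives 0.8 nM. Among the compounds with values here, the one measured step between neighbouring structures is a 58-fold lower number from compound 1 to compound 2 (1.76 log units; beyond the scatter), where the hydroxy on the sulfonyl sulfur became morpholin-4-yl.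

Compound 4 `CCn1c(=O)c2nc(-c3ccc(S(=O)(=O)N4CCSCC4)cc3)[nH]c2n(CC)c1=O` differs from compound 2 in a single spot: thiomorpholin-4-yl in place of morpholin-4-yl on a sulfonyl sulfur. The ring on the sulfonyl sulfur keeps its size and its count of hetero atoms; only the oxygen in that ring is exchanged for a sulfur. Within the data shown here, no measured step covers this exchange. The step from compound 1 to compound 2 replaced a hydroxy with a whole ring, which is a different kind of change and offers no direct guide here. With nothing in the data pointing one way, the expectation is a step of no change at the digits printed from compound 2 to compound 4 (within the scatter), that is, no change beyond the scatter. Compound 4 is therefore estimated at 13 nM, with a likely range from 5 nM to 35 nM.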

Compound 4, half-maximal inhibitory concentration: 36.6 nM
Compound 4: the middle estimate sits 2.8-fold (0.45 log units) below what was measured; measured number outside the range, above it.
By their numbers in this assay, from the lowest: compound 3; then compound 2; then compound 4; then compound 1.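

In this assay the group on the sulfonyl sulfur responds to a single atom: with ring size and hetero atom count unchanged, thiomorpholin-4-yl in place of morpholin-4-yl gives a 2.8-fold higher number from compound 2 to compound 4 (0.45 log units; beyond the scatter) as a modest step. The large step away from the hydroxy also holds for this second ring, with a 21-fold lower number from compound 1 to compound 4 (1.31 log units; beyond the scatter) as its measure, so it is not confined to morpholin-4-yl. No supporting data are available to explain why the sulfur ring gives the higher number.

The compounds shown leave open how a piperidin-1-yl ring, with a carbon where the oxygen or sulfur stands, or an open-chain dimethylamino group would behave on the sulfonyl sulfur. Compound 3 differs from these compounds in more than one place, so it does not settle this.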